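The compounds below may be only part of what the source reports. "The series", "measured", "known", "first", "only" and "open" are said of these compounds alone.

Working notes on the series. The shared core is held constant; only the group on the ring amine nitrogen varies. Compound 1 `CCCCNc1nc(N)nc2c1CN(C)CC2` carries a methyl there and in an assay on HEK293 cells for agonist activity at Toll-like receptor 8 (Homo sapiens), read by a luciferase reporter, with a stated time of 6 h (a lower number here means that less compound is needed, a higher number that more compound is needed for the effect), compound 1 gives 0.03 uM, the lowest number of the three measured. Compound 2 `CCCCNc1nc(N)nc2c1CN(Cc1ccc(OC(F)(F)F)cc1)CC2` gives 0.24 uM and compound 3 `CCCCNc1nc(N)nc2c1CN(Cc1ccc(-c3ccccc3)cc1)CC2` gives 0.5 uM. For the measured compounds named here, the one single-point step among them, a 2.1-fold higher number from compound 2 to compound 3 (0.32 log units; beyond the scatter), shows that exchanging one aryl substituent for another shifts the number only modestly; the larger gap lies between compound 1 and either of the two arylmethyl compounds.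

Compound 4 `CCCCNc1nc(N)nc2c1CN(Cc1cccnc1)CC2` is the next member, differing from compound 1 by pyridin-3-yl in place of hydrogen on a saturated chain carbon bound to an amine nitrogen in a ring. Going by the values given here, no measured step covers exactly this change, but compound 2 and compound 3 both carry an arylmethyl group on the same nitrogen and both sit well above compound 1. By that reading, a rise of similar size is expected, so compound 4 is estimated at 0.2 uM (range 0.07 uM to 0.6 uM), a step of a 6.7-fold higher number from compound 1 to compound 4 (0.82 log units; beyond the scatter) above compound 1.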

Compound 4, minimum effective concentration: 0.13 uM
Compound 4: middle estimate off by 1.5-fold (0.19 log units), on the high side, within the range that was stated.
By their numbers in this assay, from the lowest: compound 1; then compounds 4 and 2 (each within the scatter of the next); then compound 3.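

In this assay the change from methyl to (pyridin-3-yl)methyl gives a 4.3-fold higher number from compound 1 to compound 4 (0.64 log units; beyond the scatter), so a rise at this position now rests on a single measured change rather than on a gap between compounds that differ in more than one way. It also shows that the rise occurs with an aromatic ring carrying a hetero atom, as compound 4 at 0.13 uM and compound 2 at 0.24 uM stand within the scatter of each other. No measurement bearing on the origin of this step is available.

As far as these compounds go, whether the rise belongs to the aromatic ring or to any extension of the methyl stays open, and an ethyl or a longer chain would address that. From the compounds shown here alone, how a plain phenyl would read in place of pyridin-3-yl, and so what the ring nitrogen contributes, also stays open.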